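A few compounds are considered here, and "the series" means these few. Any claim that something is new, unique, unknown or untested is made for them only; others in the source may bear on it.

Three compounds share one core and differ only in the length of the saturated chain on the sulfonyl sulfur. Compound 1 `CCCCCCCCCCCCS(=O)(=O)c1ccc(O)c(C(=O)Nc2ccc(C(F)(F)F)cc2)c1` gives 8.46 in a physicochemical assay for lipophilicity; on this read-out higher numbers stand for higher lipophilicity and lower numbers for lower lipophilicity. Compound 2 `CCCCCCS(=O)(=O)c1ccc(O)c(C(=O)Nc2ccc(C(F)(F)F)cc2)c1` gives 5.22 in this assay, and compound 3 `CCCCCCCCCCS(=O)(=O)c1ccc(O)c(C(=O)Nc2ccc(C(F)(F)F)cc2)c1` gives 7.38 in this assay. Compound 3 thus stands second highest of the three: the nearest number belongs to compound 1, with a number 1.08 log units lower from compound 1 to compound 3 (beyond the scatter), and the furthest to compound 2, with a number 2.16 log units higher from compound 2 to compound 3 (beyond the scatter). Compound 4 `CCCCCCCCS(=O)(=O)c1ccc(O)c(C(=O)Nc2ccc(C(F)(F)F)cc2)c1` has not yet been measured in this assay. Its change from compound 3 is hydrogen in place of ethyl on a saturated chain carbon, eight bonds along the chain from a sulfonyl sulfur. The step that bears most directly on it is the one of the same kind further out along the chain, a number 1.08 log units lower from compound 1 to compound 3 (beyond the scatter); the longer steps of a number 3.24 log units lower from compound 1 to compound 2 (beyond the scatter) and a number 2.16 log units higher from compound 2 to compound 3 (beyond the scatter) point in the same direction, and all three lie beyond the scatter. A downward step of about that size is therefore expected, a number 1.08 log units lower from compound 3 to compound 4 (beyond the scatter). Compound 4 is expected to read 6.3 in this assay, within a range from 5.9 to 6.7.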

Compound 4, partition coefficient: 6.3
Estimate against measurement, compound 4: no gap at the digits printed; measured number inside the range.
By their numbers in this assay, from the lowest: compound 2; then compound 4; then compound 3; then compound 1.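

In this assay, taking ethyl off at this place, eight bonds along the chain from a sulfonyl sulfur, gives a number 1.08 log units lower from compound 3 to compound 4 (beyond the scatter) and so matches the step further out, a number 1.08 log units lower from compound 1 to compound 3 (beyond the scatter) in size. The step further in, a number 1.08 log units higher from compound 2 to compound 4 (beyond the scatter), is the same size again, so the read-out climbs in even steps across compounds 2, 4, 3 and 1, and none of the four goes against this. The longer step, a number 2.16 log units lower from compound 1 to compound 4 (beyond the scatter), is simply the sum of the two ethyl steps it spans. No evidence is available that accounts for this evenness.

The compounds shown leave open whether the even steps continue with a longer chain or a much shorter one, such as propyl or methyl. They also leave open whether the pattern survives an amine or a carboxylic acid at the chain end.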